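A few compounds are considered here, and "the series" means these few. Any claim that something is new, unique, unknown or untested is made for them only; others in the source may bear on it.

Compound 1 `CCOC(=O)/C=C/c1ccc(OCc2nc(C)c(C)nc2C)c(O)c1`: 139000 nM
Compound 2 `Cc1nc(C)c(COc2ccc(/C=C/C(=O)O)cc2)nc1C`: 86000 nM

In a functional assay on ECV-304 cells (Homo sapiens) for cytotoxicity, read by MTT assay, with stated times of 24 h and 12 h (on this read-out lower numbers stand for an effect already at smaller amounts and higher numbers for an effect only at larger amounts of compound), compound 2 gives 86000 nM and compound 1 gives 139000 nM so the two values lie within the scatter of each other. Compound 3 `Cc1nc(C)c(COc2ccc(/C=C/C(=O)O)cc2O)nc1C` differs from compound 2 by hydroxy in place of hydrogen on an aromatic carbon with hydroxy in place of hydrogen on an aromatic carbon. Among the compounds with values here, no measured pair isolates this change, so in this assay no step beyond the scatter is expected, in either direction. The estimated step is a 1.0-fold higher number from compound 2 to compound 3 (0.02 log units; within the scatter) and is expected to stay within the scatter. Compound 3 is estimated at 90000 nM with an expected range from 40000 nM to 200000 nM for its measurement.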

Compound 3, half-maximal effective concentration: 46000 nM
For compound 3 the middle estimate is 2.0-fold (0.29 log units) above the measured one, and the stated range covers the measured number.
By their numbers in this assay, from the lowest: compounds 3, 2 and 1 (each within the scatter of the next, the first and the last beyond it).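

Hydroxy in place of hydrogen on the aromatic carbon ortho to a large group gives a 1.9-fold lower number from compound 2 to compound 3 (0.27 log units; within the scatter) in this assay so this change alone stays inside the usual spread. With that hydroxy kept, hydrogen in place of ethyl on the oxygen next to a carbonyl group gives a 3.0-fold lower number from compound 1 to compound 3 (0.48 log units; beyond the scatter) and this is the only single change shown that passes the scatter. Nothing at hand accounts for the size of either step. From the compounds shown here alone, whether a methoxy group or an amine on that aromatic carbon would step beyond the scatter remains open. So does whether the ethyl change would give a similar step without the hydroxy.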